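The source may hold more compounds than are shown below. What is called first, only, known or untested is meant among the compounds shown, and "the series" means these compounds.

Three compounds in the series have numbers in a physicochemical assay for lipophilicity, measured as octanol-water partition, at pH 7.4; a higher number here means a more lipophilic compound, a lower number a more polar compound. Compound 1 (`Cc1ccc2[nH]c(C(=O)N[C@H]3CN(S(=O)(=O)C4CCOCC4)C[C@@H]3C(=O)NCCN(C)C)cc2c1`) gives 1, compound 2 (`Cc1ccc2[nH]c(C(=O)N[C@H]3CCN(S(=O)(=O)c4cccnc4)C[C@@H]3C(=O)NCCN(C)C)cc2c1`) gives 1.3, and compound 3 (`Cc1ccc2[nH]c(C(=O)N[C@H]3CN(S(=O)(=O)c4ccccc4)C[C@@H]3C(=O)NC[C@H]3CCCN3)cc2c1`) gives 1. All three lie within the scatter of one another, and compound 3 stands level with compound 1. Going by the values given here, no two measured compounds differ in one place only, so the series offers no measured step to use as a guide.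

Compound 4 (`Cc1ccc2[nH]c(C(=O)N[C@H]3CN(S(=O)(=O)c4ccccc4)C[C@@H]3C(=O)NC[C@@H]3CCCN3C)cc2c1`) still awaits measurement. It differs from compound 3 on a saturated chain carbon bound to an amide-type nitrogen (1-methylpyrrolidin-2-yl in place of pyrrolidin-2-yl on a saturated chain carbon bound to an amide-type nitrogen), with 1-methylpyrrolidin-2-yl in place of pyrrolidin-2-yl. A modest upward step in this assay is expected, though this expectation rests on the structural change alone. The expected step, a number 0.40 log units higher from compound 3 to compound 4 (beyond the scatter), is small and could still fall within the scatter. For compound 4 the estimated value is 1.4, with an expected range of 0.9 to 1.9.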

Compound 4, distribution coefficient: 2.3
The estimate for compound 4 lay 0.90 log units below the measured number, and the stated range ends below it.
By their numbers in this assay, from the lowest: compounds 1, 3 and 2 (each within the scatter of the next); then compound 4.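

On a saturated chain carbon bound to an amide-type nitrogen, 1-methylpyrrolidin-2-yl in place of pyrrolidin-2-yl gives a number 1.30 log units higher from compound 3 to compound 4 (beyond the scatter) in this assay, so this position can move the number by a large amount, which compounds 1, 2 and 3, all within the scatter of one another, gave no sign of. The computed difference is small for a step of this size: the group in compound 4 has 6 heavy atoms where the group in compound 3 has 5, and the group in compound 4 has 0 hydrogen-bond donors where the group in compound 3 has 1. Nothing available explains the size of the step.

On these data alone, it remains open whether an ethyl or an acetyl group in place of the methyl on the ring nitrogen would give a step of similar size. Going by these compounds alone, it is also open whether the same step would appear with a different sulfonyl group, such as the one in compound 1.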